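Naphthalen-2-yl for Methoxyphenyl: Cytotoxicity of Compound 4

The compounds below may be only part of what the source reports. "The series", "measured", "known", "first", "only" and "open" are said of these compounds alone.

The measured compounds are compound 1 `CCCCOc1ccc(-c2nc3ncccn3c2NCCC)cc1`, compound 2 `CCCCOc1ccc(-c2nc3ncccn3c2NC(C)(C)CC(C)(C)C)cc1` and compound 3 `CCCCOc1ccc(-c2nc3ncccn3c2NCc2ccc(OC)cc2)cc1`. In a toxicity assay on A549 cells (Homo sapiens) for cytotoxicity, read by luminescence and CellTiter-Glo, with a stated time of 48 h (on this read-out lower numbers stand for higher toxicity in this test and higher numbers for lower toxicity in this test), compound 1 reaches only the limit > 100000 nM, which is not a number. Compound 2 gives 29000 nM in this assay. Compound 3 gives 55000 nM in this assay. Among the two numbers shown, compound 3 has the higher one, and its nearest neighbour is compound 2, with a 1.9-fold higher number from compound 2 to compound 3 (0.28 log units; within the scatter). The limit of compound 1 is noted as the limit of > 100000 nM in this assay, at which 1 of the 3 values shown sits.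

Compound 4 `CCCCOc1ccc(-c2nc3ncccn3c2NCc2ccc3ccccc3c2)cc1` is not yet measured. It differs from compound 3 by naphthalen-2-yl in place of 4-methoxyphenyl on a saturated chain carbon bound to a nitrogen on an aromatic ring. Within the data shown here, two steps bear on this change. At the same place, the step from compound 1 to compound 3 was an at least 1.8-fold lower number from compound 1 to compound 3 (0.25 log units; that floor lies within the scatter). A change of the group on the ring nitrogen gave an at least 3.4-fold lower number from compound 1 to compound 2 (0.53 log units; beyond the scatter). Both point to lower numbers with bulkier groups, but neither clearly beyond the scatter. For compound 4 a step of a 1.6-fold lower number from compound 3 to compound 4 (0.20 log units; within the scatter) is therefore expected, no larger than the scatter. Compound 4 is expected to give 35000 nM, between 12000 nM and 100000 nM.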

Compound 4, half-maximal cytotoxic concentration: 33000 nM
For compound 4 the middle estimate is 1.1-fold (0.03 log units) above the measured one, and the stated range covers the measured number.
By their numbers in this assay, from the lowest: compounds 2, 4 and 3 (each within the scatter of the next). At a limit, above all of these: compound 1.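

In this assay, the place on a saturated chain carbon bound to a nitrogen on an aromatic ring now holds a second aromatic group. Naphthalen-2-yl, which has no oxygen and 2 six-membered aromatic rings of carbon only, replaces 4-methoxyphenyl with a 1.7-fold lower number from compound 3 to compound 4 (0.22 log units; within the scatter), so this assay does not tell these two groups apart. Measured against ethyl at that place, naphthalen-2-yl gives an at least 3.0-fold lower number from compound 1 to compound 4 (0.48 log units; beyond the scatter), which clears the scatter where the floor of the step to compound 3 did not, though it remains a floor since compound 1 stands at a limit, which is not a number: the limit of > 100000 nM in this assay, at which 1 of the 4 values shown sits.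

The compounds shown leave open how an amine or a carboxylic acid at this place would read in this assay. They also leave open whether a longer chain between that nitrogen and the naphthalen-2-yl group would change the number.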